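Returning to a Fluorinated Phenyl Ring: An Expected Gain

The source may report more compounds than this note shows. Statements on the series, on what has been measured and on what is new or still open speak of the compounds shown alone.

Measured so far:
Compound 1, `CC(C)OC(=O)N1CCC(Oc2ncnc3c2CCN3c2ccc(C#N)cc2F)CC1`: 134%
Compound 2, `CC(C)OC(=O)N1CCC(Oc2ncnc3c2CCN3c2ccc(C#N)cn2)CC1`: 105%

Within the data shown here, in a functional assay on CHO-K1 cells with Glucose-dependent insulinotropic receptor (Homo sapiens) as the target, read by a luciferase reporter, with a stated time of 5 h (a higher number here means a larger maximal response, a lower number a smaller maximal response), compound 2 holds the lower of the two numbers measured so far; the single measured step, a number 29 percentage points lower from compound 1 to compound 2 (beyond the scatter), is the only change known here, and it lies beyond the scatter. Compound 3, `CC(C)OC(=O)N1CCC(Oc2ncnc3c2CCN3c2ccc(C#N)c(F)c2)CC1`, differs from compound 2 in one place: 4-cyano-3-fluorophenyl in place of 5-cyanopyridin-2-yl on a nitrogen on an aromatic ring in a ring.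

This change is close to the reverse of the measured step. Going from compound 1 to compound 2 replaced a carbon-only ring carrying a nitrile and a fluorine with the pyridinyl ring and lowered the maximal response modestly. Compound 3 brings back a carbon-only ring with a nitrile and a fluorine, though as 4-cyano-3-fluorophenyl rather than the 4-cyano-2-fluorophenyl of compound 1, so the return is not exact.

Because of a number 29 percentage points lower from compound 1 to compound 2 (beyond the scatter), a gain of similar size is expected for compound 3, namely a number 20 percentage points higher from compound 2 to compound 3 (beyond the scatter). Compound 3 is therefore estimated at 125%, within a range from 100% to 150%, with the wider range reflecting the changed fluorine group.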

Compound 3, largest response reached (reported as percent of maximum), in percent of the reference or control that the assay uses: 121%
Estimate against measurement, compound 3: 4 percentage points above; measured number inside the range.
By their numbers in this assay, from the lowest: compound 2; then compound 3; then compound 1.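

In this assay, the swap at this place on the ring nitrogen of the core pays off in the other direction as well, with a number 16 percentage points higher from compound 2 to compound 3 (beyond the scatter), so both rings here that carry a nitrile and a fluorine on carbon alone stand above the 5-cyanopyridin-2-yl ring of compound 2. The two fluorinated rings are not interchangeable, however, with a number 13 percentage points lower from compound 1 to compound 3 (beyond the scatter), which shows that the maximal response depends on the arrangement of the groups on the ring and not merely on their presence, with 4-cyano-2-fluorophenyl ahead of 4-cyano-3-fluorophenyl. No measurement available here explains either difference.

Going by these compounds, the step from the pyridinyl ring to the phenyl ring exchanges a ring nitrogen and adds a fluorine in a single move, so the share of each remains unknown, and a plain 4-cyanophenyl ring would help to separate them. On these data alone, it also remains open how far the response can be pushed at this place by other groups on the ring, such as a chlorine in place of the fluorine or a methoxy group in place of the nitrile.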